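Phenyl in Place of Benzyl on an Amide-Type Nitrogen

The compounds below may be only part of what the source reports. "The series", "measured", "known", "first", "only" and "open" are said of these compounds alone.

Compound 1 `COc1ccc(CN(C(=O)Nc2ccc(Cl)cc2)n2cnnc2)cc1OC` — in a functional assay on MCF7 cells (Homo sapiens) for cytotoxicity, read by MTT assay, with a stated time of 48 h (a lower number here means a stronger inhibitor, a higher number a weaker inhibitor), compound 1 gives > 50000 nM, which is a limit of the assay.
Compound 2 `COc1ccc(CN(C(=O)Nc2ccc(F)c(Cl)c2)n2cnnc2)cc1OC` — in this assay compound 2 gives 30100 nM.
Compound 3 `O=C(NCc1ccccc1)N(Cc1ccccn1)n1cnnc1` — in this assay compound 3 gives > 50000 nM, again a limit rather than a number.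

Compound 3 therefore stands at the limit of > 50000 nM in this assay, at which 2 of the 3 values shown sit. Compound 4 `O=C(Nc1ccccc1)N(Cc1ccccn1)n1cnnc1` differs from it by phenyl in place of benzyl on an amide-type nitrogen. Within the data shown here, the only measured step, an at least 1.6-fold lower number from compound 1 to compound 2 (0.22 log units; that floor lies within the scatter), changes a substituent on an aromatic ring and does not touch the benzyl-to-phenyl exchange, so no measured step bears on this change. With nothing pointing either way, compound 4 is expected to stay near the limit, a step of a number no higher from compound 3 to compound 4 (the limit leaves the size open). The estimate for compound 4 is 50000 nM, within 20000 nM to 120000 nM.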

Compound 4, half-maximal inhibitory concentration: > 50000 nM
Compound 4: only a limit was reported; the forecaster's own chance of this, stated with the estimate: 70%; the middle value sits exactly at the limit.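

Compound 3 and compound 4 each give only a limit rather than a number, so the step between them cannot be read: the limit of > 50000 nM in this assay, at which 3 of the 4 values shown sit.

As far as these compounds go, whether phenyl in place of benzyl on an amide-type nitrogen changes the result in this assay at all stays open.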